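The source may hold more compounds than are shown below. What is called first, only, known or untested is meant among the compounds shown, and "the series" means these compounds.

In a functional assay on KYSE-70 cells for antiproliferative activity against KYSE-70 cell line (Homo sapiens), read by MTT assay, with a stated time of 72 h (a higher number here means a weaker inhibitor, a lower number a stronger inhibitor), compound 1 `O=C(Nc1cccc(F)c1)c1cc(=O)[nH]c2cc(-c3ccc(F)cc3)ccc12` gives 3300 nM as a measured number. In this assay compound 2 `Nc1ccc(-c2ccc3c(C(=O)Nc4cccc(F)c4)cc(=O)[nH]c3c2)cc1` stands only at a limit, > 20000 nM, so it has no exact number. Within the data shown here, the single measured step, amino in place of fluoro on an aromatic carbon, is an at least 6.0-fold higher number from compound 1 to compound 2 (0.78 log units; beyond the scatter), and it is the only step that bears on the next change. Compound 3 `O=C(Nc1cccc(F)c1)c1cc(=O)[nH]c2cc(C3=CCOCC3)ccc12` is reached from compound 2 by a larger change: a group of 6 heavy atoms (5 carbon, 1 oxygen; one six-membered non-aromatic ring with 1 hetero atom) in place of a group of 7 heavy atoms (6 carbon, 1 nitrogen; one six-membered aromatic ring of carbon only), on an aromatic carbon. Among the measured compounds shown here, the 4-aminophenyl leaves whole, so the amino group of that step goes, but its aromatic ring goes too, and no measured compound carries the entering group. With compound 1 at 3300 nM as the only numbered reference, a move to a lower number in this assay is expected, though probably not all the way back to that value. The expected change is an at least 2.5-fold lower number from compound 2 to compound 3 (0.39 log units; beyond the scatter), modest in size and uncertain, and a second reading at the limit remains possible. For compound 3 the estimated value is 8000 nM, with an expected range from 2500 nM to 20000 nM.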

Compound 3, half-maximal inhibitory concentration: 10500 nM
For compound 3 the middle estimate is 1.3-fold (0.12 log units) below the measured one; the measured number falls inside the stated range.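

Among these compounds, compound 3 shows that a group with no aromatic ring can sit at this position on the shared core and still give a measured number in this assay, yet the one exact comparison is a 3.2-fold higher number from compound 1 to compound 3 (0.50 log units; beyond the scatter), so the fluorine-bearing aromatic group of compound 1 remains the better of the two in this pair. The other reading is an at least 1.9-fold lower number from compound 2 to compound 3 (0.27 log units; that floor lies within the scatter), and as that floor lies within the scatter, it does not firmly establish that the entering ring improves on the 4-aminophenyl group. Compound 2 has only a limit of the assay, not a number, so the true size of this step stays unknown: the limit of > 20000 nM in this assay, at which 1 of the 3 values shown sits.

As far as these compounds go, it remains open whether the ring oxygen or the double bond matters, which a cyclohexenyl group or a saturated tetrahydropyranyl group at the same place would test. From the compounds shown here alone, how a piperidine ring, with nitrogen in place of the oxygen, would read in this assay is also open.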